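The source may hold more compounds than are shown below. What is called first, only, known or untested is meant among the compounds shown, and "the series" means these compounds.

Compound 1 `CCCCc1nc(C)c(CCC(=O)OCC)c(=O)n1Cc1ccc(-c2ccccc2-c2nnn[nH]2)cc1` and compound 2 `CCCCc1nc(C)c(CC(=O)O)c(=O)n1Cc1ccc(-c2ccccc2-c2nnn[nH]2)cc1` were both tested in an in vivo functional assay on the whole organism for inhibition, with Rattus norvegicus as the target; on this read-out higher numbers stand for an effect only at larger amounts of compound and lower numbers for an effect already at smaller amounts. Compound 1 gives 0.066 mg/kg and compound 2 gives 0.13 mg/kg. These numbers show a 2.0-fold higher number from compound 1 to compound 2 (0.29 log units; within the scatter), so compound 2 cannot be told apart from compound 1. For compound 3 `CCCc1nc(C)c(CC(=O)O)c(=O)n1Cc1ccc(-c2ccccc2-c2nnn[nH]2)cc1` the entry is "not determined" (no result reported). Compound 4 `CCCCc1nc(C)c(CC(=O)N(C)C)c(=O)n1Cc1ccc(-c2ccccc2-c2nnn[nH]2)cc1` keeps the core of compound 2 but carries dimethylcarbamoyl instead of carboxy: dimethylamino in place of hydroxy on a carbonyl carbon. For the measured compounds named here, the one measured step that bears on this, a 2.0-fold higher number from compound 1 to compound 2 (0.29 log units; within the scatter), also replaces a group on that chain, so no step beyond the scatter is expected in this assay, although a single step is thin evidence. The estimated step is a 1.2-fold higher number from compound 2 to compound 4 (0.06 log units; within the scatter). For compound 4 the estimate is 0.15 mg/kg, with an expected range of 0.04 mg/kg to 0.6 mg/kg.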

Compound 4, dose for half-maximal effect: 0.018 mg/kg
The estimate for compound 4 lay 8.3-fold (0.92 log units) above the measured number; the whole stated range lies above it.
By their numbers in this assay, from the lowest: compound 4; then compounds 1 and 2 (each within the scatter of the next).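

In this assay the end of this chain turns out to matter: the earlier change there stayed within the scatter, whereas dimethylamino in place of hydroxy on the carbonyl carbon gives a clear step (a 7.2-fold lower number from compound 2 to compound 4 (0.86 log units; beyond the scatter)). Compound 4 also separates from the ester (a 3.7-fold lower number from compound 1 to compound 4 (0.56 log units; beyond the scatter)). Nothing measured here accounts for these steps.
Still open, going by these compounds, is whether both methyl groups of the dimethylamino are needed, since a plain amino group on the same carbonyl carbon could behave differently. A ring amine such as pyrrolidine in that place is equally untested by these compounds.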